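The compounds below may be only part of what the source reports. "The series", "measured", "known", "first", "only" and "open" are said of these compounds alone.

Working notes on the series.

Three compounds have been run in a physicochemical assay for lipophilicity, read by HPLC, measured as octanol-water partition; on this read-out lower numbers stand for lower lipophilicity and higher numbers for higher lipophilicity. Compound 1 `COc1ccc(N(CC(=O)NCCC[Te]c2ccccc2)C(=O)c2ccccc2)cc1` gives 1.72. Compound 2 `COc1ccc(N(CC(=O)NCCCSc2ccccc2)C(=O)CCSC2=C(C)C(=O)c3ccccc3C2=O)cc1` gives 4.2. Going by the values given here, compound 3 `COc1ccc(N(CC(=O)NCCC[Te]c2ccccc2)C(=O)/C=C/c2ccccc2)cc1` gives 1.31, the lowest of the three numbers; compound 1 is the nearest, and the only step within this set that changes a single place, a number 0.41 log units lower from compound 1 to compound 3 (beyond the scatter), is a modest one beyond the scatter. Compound 2 stands furthest from compound 3 and differs from it in more than one place, so its value is noted only as the highest of the three.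

The next compound, compound 4 `COc1ccc(N(CC(=O)NCCCSc2ccccc2)C(=O)/C=C/c2ccccc2)cc1`, differs from compound 3 by a group of 7 heavy atoms (6 carbon, 1 sulfur; one six-membered aromatic ring of carbon only) in place of a group of 7 heavy atoms (6 carbon, 1 tellurium; one six-membered aromatic ring of carbon only), on a saturated chain carbon, three bonds along the chain from an amide-type nitrogen. Among the compounds with values here, no measured step in this assay bears on this exchange: compound 2 carries the entering group, but alongside other changes, and no pair shows the two groups swapped alone. The step of a number 0.11 log units lower from compound 3 to compound 4 (within the scatter) is therefore expected to be small, within or near the scatter. Compound 4 is estimated at 1.2, with a range from 0.6 to 1.8.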

Compound 4, partition coefficient: 4
The estimate for compound 4 lay 2.80 log units below the measured number, outside the stated range (above it).
By their numbers in this assay, from the lowest: compound 3; then compound 1; then compounds 4 and 2 (each within the scatter of the next).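

In this assay, going by these compounds alone, the phenylsulfanyl group entering in place of the tellurium-bearing group, on a saturated chain carbon, three bonds along the chain from an amide-type nitrogen, gives the first reading of this exchange alone: a number 2.69 log units higher from compound 3 to compound 4 (beyond the scatter). This large step outweighs the modest one at the carbonyl carbon, a number 0.41 log units lower from compound 1 to compound 3 (beyond the scatter), so this chain position carries the bigger change of the two single-place steps in the set. Nothing measured here accounts for the size of the step.

From the compounds shown here alone, whether the exchange gives a similar step with phenyl on the carbonyl carbon, as in compound 1, remains open. Also open, going by these compounds, is how phenoxy or phenylselanyl would read at this position, and whether a longer chain would alter the step.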